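This account rests on a few compounds, and the source may have more. Where it says the series, first, only, none or still open, it means among the compounds named here.

In a functional assay on the whole organism (blood) with Rattus norvegicus as the target, with stated times of 24 h and 1 h, at a dose of 5 mg/kg by the intraperitoneal route (on this read-out higher numbers stand for a stronger effect at the one dose given and lower numbers for a weaker effect), compound 3 `COc1ncccc1C(=O)NCCC1CCN(S(=O)(=O)NC(=O)NC2CCCCC2)CC1` gives 33%. Compound 1 `O=C(NC1CCCCC1)NS(=O)(=O)N1CCC(CCNC(=O)C(F)(F)F)CC1` gives 13%, and compound 2 `O=C(NC1CCCCC1)NS(=O)(=O)N1CCC(CCNC(=O)c2cscn2)CC1` gives 23%. The step of a number 20 percentage points higher from compound 1 to compound 3 (beyond the scatter) lies beyond the scatter, while the step of a number 10 percentage points higher from compound 2 to compound 3 (within the scatter) lies within it, so compound 3 stands apart only from compound 1. Compound 4 `COc1ncccc1C(=O)NCCC1CCN(S(=O)(=O)NC(=O)NCC2CCCO2)CC1` differs from compound 3 by (oxolan-2-yl)methyl in place of cyclohexyl on an amide-type nitrogen. Among the measured compounds shown here, the three measured steps, a number 10 percentage points higher from compound 1 to compound 2 (within the scatter), a number 20 percentage points higher from compound 1 to compound 3 (beyond the scatter) and a number 10 percentage points higher from compound 2 to compound 3 (within the scatter), all concern the group on the carbonyl carbon at the far end of the shared core, and none of them touches the amide-type nitrogen where compound 4 changes, so no measured step bears directly on this change. The numbers give no direction for it. For compound 4 the step of a number 5 percentage points lower from compound 3 to compound 4 (within the scatter) is expected to stay within the scatter, with wide uncertainty. Compound 4 is therefore estimated at 28%, with a range from 10% to 45%.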

Compound 4, a percentage reported as activity, at one dose (the size of the read-out at that dose, not a potency): 16%
The estimate for compound 4 lay 12 percentage points above the measured number, within the range that was stated.
By their numbers in this assay, from the lowest: compounds 1, 4, 2 and 3 (each within the scatter of the next, the first and the last beyond it).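

In this assay, among the compounds shown here, the step of a number 17 percentage points lower from compound 3 to compound 4 (beyond the scatter) shows that the read-out also responds to the group on the amide-type nitrogen, a place that none of the earlier steps touched. The change keeps the count of 6 heavy atoms but replaces a six-membered ring of carbon only with a five-membered ring holding 1 hetero atom, and it adds 1 hydrogen-bond acceptor. No evidence is available to explain this fall.

The compounds shown leave open whether a cyclopentylmethyl group, which has the five-membered ring without the oxygen, or a tetrahydropyran-4-yl group, which has the oxygen in a six-membered ring, would stay closer to cyclohexyl. They also leave open whether the same change on this nitrogen would give a similar step with 1,3-thiazol-4-yl or trifluoromethyl on the carbonyl carbon.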